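The source may hold more compounds than are shown below. What is called first, only, known or untested is meant among the compounds shown, and "the series" means these compounds.

Compound 1 `CCCCCCCCNC(=O)[C@@H](NC(=O)c1cc2ccccc2o1)[C@@H](C)O` gives 200000 nM in a functional assay on SW-620 cells (Homo sapiens) for cytotoxicity, read by MTT assay, with a stated time of 48 h; on this read-out lower numbers stand for stronger inhibition and higher numbers for weaker inhibition.
Compound 2 `CCCCCCCCNC(=O)[C@@H](NC(=O)/C=C/c1ccccc1)[C@@H](C)O` gives 61400 nM in this assay.

Compound 2 has the lowest of the two numbers; its nearest neighbour is compound 1, set apart by a 3.3-fold lower number from compound 1 to compound 2 (0.51 log units; beyond the scatter). Compound 3 `CCCCCCCCCCCCCCNC(=O)[C@@H](NC(=O)/C=C/c1ccccc1)[C@@H](C)O` differs from compound 2 by hexyl in place of hydrogen on a saturated chain carbon, eight bonds along the chain from an amide-type nitrogen. Among the measured compounds shown here, no measured step bears on this change: the only step available, a 3.3-fold lower number from compound 1 to compound 2 (0.51 log units; beyond the scatter), concerns the group on the carbonyl carbon and says nothing about the chain. A modest move is therefore expected, a 2.0-fold lower number from compound 2 to compound 3 (0.31 log units; beyond the scatter). Compound 3 is estimated at 30000 nM, within a range from 8000 nM to 120000 nM.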

Compound 3, half-maximal inhibitory concentration: 200000 nM
Compound 3: the middle estimate sits 6.7-fold (0.82 log units) below what was measured, and the stated range ends below it.
By their numbers in this assay, from the lowest: compound 2; then compounds 1 and 3 (each within the scatter of the next).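

Among the compounds shown here, the chain position was untouched by the earlier compounds, and it proves sensitive to this change: in this assay hexyl in place of hydrogen, on a saturated chain carbon eight bonds along the chain from an amide-type nitrogen, gives a 3.3-fold higher number from compound 2 to compound 3 (0.51 log units; beyond the scatter). Added chain length at this position therefore weakens inhibition here, at least for this one pair. Nothing in the available evidence accounts for this shift. The compounds shown leave open whether a shorter chain would give a lower number than compound 2 does, and how an amine or a carboxylic acid in place of hexyl at this position would read.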